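A short chain in place of 4-methylphenyl

A few compounds are considered here, and "the series" means these few. Any claim that something is new, unique, unknown or untested is made for them only; others in the source may bear on it.

In an ADME assay on HFF cells (Homo sapiens) for cytotoxicity, read by MTT assay, with a stated time of 72 h (a lower number here means a stronger inhibitor, a higher number a weaker inhibitor), compound 1 `CCCCc1cn(C[C@H](O)[C@H]2OC(=O)C(OCc3ccccc3)=C2OCc2ccccc2)nn1`, which carries butyl, gives 26300 nM. Compound 2 `CCCCCCCCCCc1cn(C[C@H](O)[C@H]2OC(=O)C(OCc3ccccc3)=C2OCc2ccccc2)nn1` gives > 100000 nM, which is a limit. Compound 3 `Cc1ccc(-c2cn(C[C@H](O)[C@H]3OC(=O)C(OCc4ccccc4)=C3OCc3ccccc3)nn2)cc1` gives > 100000 nM, also a limit, so it stands at the limit of > 100000 nM in this assay, at which 2 of the 3 values shown sit.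

Compound 4 `O=C1O[C@H]([C@@H](O)Cn2cc(CCCCl)nn2)C(OCc2ccccc2)=C1OCc1ccccc1` has 3-chloropropyl in place of 4-methylphenyl on an aromatic carbon. The closest measured change is an at least 3.8-fold higher number from compound 1 to compound 3 (0.58 log units; beyond the scatter), where 4-methylphenyl replaced butyl. Lengthening the chain gave an at least 3.8-fold higher number from compound 1 to compound 2 (0.58 log units; beyond the scatter), and a step that the two limits leave unreadable from compound 2 to compound 3 adds nothing. The short chain of compound 4 resembles the butyl of compound 1, so a return towards its value is expected. The expected change is an at least 2.8-fold lower number from compound 3 to compound 4 (0.45 log units; beyond the scatter). Compound 4 is estimated at 35000 nM, within 12000 nM to 100000 nM.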

Compound 4, half-maximal inhibitory concentration: 27100 nM
The estimate for compound 4 lay 1.3-fold (0.11 log units) above the measured number; low and high end bracket the measured number.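

In this assay, 3-chloropropyl at this position on the triazole gives an at least 3.6-fold lower number from compound 3 to compound 4 (0.56 log units; beyond the scatter), and against the decyl chain it gives an at least 3.6-fold lower number from compound 2 to compound 4 (0.56 log units; beyond the scatter). Swapping the end of the short chain from methyl to chloro changes nothing readable, with a 1.0-fold higher number from compound 1 to compound 4 (0.01 log units; within the scatter), so a short chain carries this level whichever of the two ends it. The comparison partners compound 2 and compound 3 each rest on a limit, not a number: the limit of > 100000 nM in this assay, at which 2 of the 4 values shown sit.

From the compounds shown here alone, whether an amine or a carboxylic acid in place of the chloro would hold this level remains open. So does where an octyl chain would fall between butyl and decyl.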